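A few compounds are considered here, and "the series" means these few. Any claim that something is new, unique, unknown or untested is made for them only; others in the source may bear on it.

In an ADME assay on HaCaT cells (Homo sapiens) for inhibition, read by sulforhodamine B assay, with a stated time of 48 h (on this read-out lower numbers stand for stronger inhibition of growth and higher numbers for weaker inhibition of growth), compound 2 `COc1ccc(/C=C/C2CC=CC(=O)O2)cc1` gives 58.8 uM, the lowest of the two numbers recorded so far; its nearest neighbour is compound 1 `O=C1C=CCC(/C=C/c2ccc(C(F)(F)F)cc2)O1`, which in this assay gives 69.7 uM, and the step of a 1.2-fold lower number from compound 1 to compound 2 (0.07 log units; within the scatter) from the one to the other is small. Compound 3 `COc1ccc(/C=C/C2CC=CC(=O)O2)cc1OC` differs from compound 2 by methoxy in place of hydrogen on an aromatic carbon. Within the data shown here, the only measured step, that from compound 1 to compound 2, concerns a change on the same aromatic ring and stayed within the scatter, so for compound 3 no step beyond the scatter is expected in this assay, about a 1.1-fold lower number from compound 2 to compound 3 (0.03 log units; within the scatter). Compound 3 is therefore estimated at 55 uM, with a range from 27 uM to 110 uM.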

Compound 3, concentration for growth inhibition (reported as GI): 63 uM
Compound 3: middle estimate off by 1.1-fold (0.06 log units), on the low side; low and high end bracket the measured number.
By their numbers in this assay, from the lowest: compounds 2, 3 and 1 (each within the scatter of the next).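

In this assay, methoxy in place of hydrogen on an aromatic carbon, ortho to a methoxy group and meta to a group of 9 heavy atoms, gives a 1.1-fold higher number from compound 2 to compound 3 (0.03 log units; within the scatter) and so leaves the read-out within the scatter. Among these compounds, the earlier compounds showed only one group exchanged for another, whereas this result shows that a second methoxy can be added to the aromatic ring with no step beyond the scatter. As far as these compounds go, whether an amine, a carboxylic acid or a longer chain at this same position would also stay within the scatter remains open. No evidence is available that explains this result.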